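A Benzyloxycarbonyl Variant of an Amide Side Chain

The source may report more compounds than this note shows. Statements on the series, on what has been measured and on what is new or still open speak of the compounds shown alone.

Three compounds of one series have been examined in a functional assay on the whole organism (Tail, strain ICR) with Mus musculus as the target, in the tail flick test, with a stated time of 150 min, at a dose of 25 umol/kg by the oral route; a lower number here means a weaker effect, a higher number a stronger effect of the compound at the dose given. Compound 1, `NC(=O)CC[C@H](NC(=O)CN(c1ncnc2c1ncn2C1CCCCO1)C1CC1)C(=O)OCc1ccccc1`, gives 10.7% in this assay. Compound 2, `NC(=O)C[C@H](NC(=O)CN(c1nc(Cl)nc2[nH]cnc12)C1CC1)C(=O)O`, gives 7.51%, and compound 3, `CC[C@H](C)[C@H](NC(=O)CN(c1nc(Cl)nc2[nH]cnc12)C1CC1)C(=O)OCc1ccccc1`, gives 6.9%. Of these three numbers, that of compound 1 is the highest, but its gap to compound 2 and its gap to compound 3 both fall within the usual scatter of such measurements, so the three compounds cannot be told apart on this evidence.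

Compound 4, `O=C(CN(c1ncnc2c1ncn2C1CCCCO1)C1CC1)N[C@@H](CC(=O)OCc1ccccc1)C(=O)OCc1ccccc1`, has not yet been measured in this assay. It differs from compound 1 in one place: benzyloxycarbonyl in place of carbamoylmethyl on a saturated chain carbon, two bonds along the chain from an amide-type nitrogen and a carbonyl carbon. The shared core of compound 1 is kept unchanged.

Among the compounds with values here, no pair of measured compounds shows a single, isolated change, so there is no measured step from which the effect of this exchange could be read. The three measured numbers all sit low and close together, and nothing in them points to a large movement in either direction. Compound 4 is therefore expected to give a number close to that of compound 1, with the step of a number 1.7 percentage points lower from compound 1 to compound 4 (within the scatter) estimated to lie within the scatter. The value estimated for compound 4 is 9%, within a range from 2% to 20%.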

Compound 4, a percentage reported as activity, at one dose (the size of the read-out at that dose, not a potency): 0.06%
For compound 4 the middle estimate is 8.9 percentage points above the measured one, and the stated range ends above it.
By their numbers in this assay, from the lowest: compounds 4, 3, 2 and 1 (each within the scatter of the next, the first and the last beyond it).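

Within the data shown here, with the exchange of carbamoylmethyl for benzyloxycarbonyl, this assay shows a step of a number 10.6 percentage points lower from compound 1 to compound 4 (beyond the scatter) and so gives the first comparison in which a single change can be read. The earlier compounds shown here offered no such comparison, and this one shows that the place on a saturated chain carbon, two bonds along the chain from an amide-type nitrogen and a carbonyl carbon, is not indifferent to the group it carries. The step is modest in size, yet compound 4 at 0.06% retains almost no read-out at the dose given, and nothing available bears on why the number falls.

The exchange removes the hydrogen-bond donor of carbamoylmethyl and brings in a six-membered aromatic ring in one step, and the compounds shown do not separate these two changes or the larger group size from one another. From the compounds shown here alone, whether a methyl ester, a carboxylic acid or a longer chain ending in a primary amide at this place would stay close to compound 1 or fall as compound 4 does remains open.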